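Extending the Anilide of a Potent Phthalazine Piperazine Acetamide

A few compounds are considered here, and "the series" means these few. Any claim that something is new, unique, unknown or untested is made for them only; others in the source may bear on it.

Compound 1 `O=C(CN1CCN(c2nnc(Cc3ccncc3)c3ccccc23)CC1)Nc1cccc(F)c1` is the strongest of the three compounds measured in a functional assay on MDA-MB-231 cells (Homo sapiens) for cytotoxicity, read by MTT assay, with a stated time of 72 h (a higher number here means a weaker inhibitor, a lower number a stronger inhibitor), where compound 1 gives 4.4 nM. Compound 2 `Cc1ccc(NC(=O)CN2CCN(c3nnc(Cc4ccccc4)c4ccccc34)CC2)c(C)c1` gives 181000 nM and compound 3 `Cc1ccccc1NC(=O)CN1CCN(c2nnc(Cc3ccccc3)c3ccccc23)CC1` gives 17300 nM; both carry a benzyl group on the shared core rather than the pyridylmethyl of compound 1, and both lie far from it, compound 3 the nearer of the two and compound 2 the further. Among the measured compounds shown here, the one recorded step, a 10-fold lower number from compound 2 to compound 3 (1.02 log units; beyond the scatter), shows that a change on the anilide ring alone can move the read-out by a large amount.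

Compound 4 `O=C(CN1CCN(c2nnc(Cc3ccncc3)c3ccccc23)CC1)Nc1ccc(F)c(C(F)(F)F)c1` differs from compound 1 in a single place: 4-fluoro-3-(trifluoromethyl)phenyl in place of 3-fluorophenyl on an amide-type nitrogen. For the measured compounds named here, no measured pair shows this same exchange, so the step from compound 2 to compound 3 is the only guide to how much an anilide change may matter. On that basis a moderate shift toward a higher number is expected for compound 4, estimated at 15 nM with a range from 2 nM to 200 nM, a step of a 3.4-fold higher number from compound 1 to compound 4 (0.53 log units; beyond the scatter) that is expected rather than known.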

Compound 4, half-maximal inhibitory concentration: 1.9 nM
Beside the measured number, compound 4's estimate is 7.9-fold (0.90 log units) above it, and the stated range ends above it.
By their numbers in this assay, from the lowest: compound 4; then compound 1; then compound 3; then compound 2.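

In this assay, the step of a 2.3-fold lower number from compound 1 to compound 4 (0.36 log units; beyond the scatter) comes with 4-fluoro-3-(trifluoromethyl)phenyl in place of 3-fluorophenyl on the amide-type nitrogen. The earlier step on the anilide ring was seen only among the weak benzyl compounds; this one shows that, with the pyridylmethyl group in place, a group of 11 heavy atoms instead of 7 can stand at this position and the number still moves modestly lower. Nothing measured here bears on why the number fell, so the step stands as an observation only.

On these data alone, compound 4 adds a trifluoromethyl group and moves the fluorine in one exchange, so the share of each in the step remains open. Also open, as far as these compounds go, is how this position would respond to an amine, a carboxylic acid or a longer chain on the anilide ring.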